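Succinimide propanamide piperazines: aryl substituent swap, chloro to trifluoromethyl

The source may hold more compounds than are shown below. What is called first, only, known or untested is meant among the compounds shown, and "the series" means these compounds.

The series is read in a functional assay on the whole organism (strain Swiss) with Mus musculus as the target, with a stated time of 0.25 h, at a dose of 300 mg/kg; a lower number here means a weaker effect, a higher number a stronger effect of the compound at the dose given. Compound 1 `CC(C(=O)N1CCN(c2ccccc2C(F)(F)F)CC1)N1C(=O)CCC1=O` gives 100%. Compound 2 `CC(C(=O)N1CCN(c2cccc(Cl)c2)CC1)N1C(=O)CCC1=O` gives 75%, the lowest of the two numbers shown; the gap to compound 1 is beyond the usual scatter, though no single-point step between these two is counted here.

Compound 3 `CC(C(=O)N1CCN(c2cccc(C(F)(F)F)c2)CC1)N1C(=O)CCC1=O` is not yet measured. Its change from compound 2 is trifluoromethyl in place of chloro on an aromatic carbon, on an aromatic carbon of a six-membered aromatic ring of carbon only, meta to a large group. Nothing measured bears directly on this exchange, so the direction is uncertain; a modest move upward from compound 2 is expected, as compound 1 with a trifluoromethyl group on the same ring shows 100%. The expected step is a number 10 percentage points higher from compound 2 to compound 3 (within the scatter). For compound 3 the estimate is 85%, with a range from 60% to 100%.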

Compound 3, a percentage reported as activity, at one dose (the size of the read-out at that dose, not a potency): 100%
The estimate for compound 3 lay 15 percentage points below the measured number, and the stated range covers the measured number.
By their numbers in this assay, from the lowest: compound 2; then compounds 1 and 3 (each within the scatter of the next).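

In this assay, among these compounds, the exchange of chloro for trifluoromethyl on an aromatic carbon, meta to a large group, gives a number 25 percentage points higher from compound 2 to compound 3 (beyond the scatter) and so provides the first single-place step. It shows that the read-out at this position responds to the identity of the substituent, which compounds 1 and 2 could not show, as they differ in more than one place. Nothing available gives a reason for this step.

Going by these compounds, whether the response follows from the larger group or from some other difference between the two stays open, and a methoxy group, a nitrile or an amine on the same carbon would help to separate these readings. On these data alone, since compound 3 gives 100% at a single dose, its potency also remains open.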